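Urea series: swapping the saturated ring on the core

A few compounds are considered here, and "the series" means these few. Any claim that something is new, unique, unknown or untested is made for them only; others in the source may bear on it.

- Compound 1 `COc1ccc(NC(=O)Nc2nc(Sc3c[nH]c4ccccc34)cc(N3CCCCC3)n2)cc1`: 7260 nM
- Compound 2 `Cc1ccc(C)c(NC(=O)Nc2nc(Sc3c[nH]c4ccccc34)cc(N3CCCCC3)n2)c1`: 5940 nM
- Compound 3 `O=C(Nc1ccccc1)Nc1nc(Sc2c[nH]c3ccccc23)cc(N2CCN(Cc3ccccc3)CC2)n1`: 10200 nM

In a functional assay on MDA-MB-231 cells (Homo sapiens) for inhibition, with a stated time of 72 h (a higher number here means a weaker inhibitor, a lower number a stronger inhibitor), compound 1 stands in the middle of the three numbers, within the scatter of both compound 2 and compound 3. Compound 4 `COc1ccc(NC(=O)Nc2nc(Sc3c[nH]c4ccccc34)cc(N3CCCC3)n2)cc1` differs from compound 1 by pyrrolidin-1-yl in place of piperidin-1-yl on an aromatic carbon. Among the measured compounds shown here, no measured step changes this position. For the measured compounds named here, the only single-place step, a 1.2-fold lower number from compound 1 to compound 2 (0.09 log units; within the scatter), concerns a different site and stayed small, so no shift beyond the scatter is expected in this assay. The expected change is a 1.1-fold lower number from compound 1 to compound 4 (0.05 log units; within the scatter). Compound 4 is estimated at 6500 nM, with an expected range of 3000 nM to 14000 nM.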

Compound 4, half-maximal inhibitory concentration: 13100 nM
For compound 4 the middle estimate is 2.0-fold (0.30 log units) below the measured one, and the stated range covers the measured number.
By their numbers in this assay, from the lowest: compounds 2, 1, 3 and 4 (each within the scatter of the next, the first and the last beyond it).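

In this assay, this position now has its first readable step: pyrrolidin-1-yl in place of piperidin-1-yl gives a 1.8-fold higher number from compound 1 to compound 4 (0.26 log units; within the scatter). Between these two saturated rings, the one-carbon difference in ring size therefore does not separate the compounds beyond the scatter. Nothing available explains this step.

Compound 3 differs from compound 1 in more than one place and gives no read on this position. Open, on these data alone, is whether morpholine or an open-chain dimethylamino group here would shift the number beyond the scatter.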